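A Methyl Added to the Hydroxyl-Bearing Chain

The compounds below may be only part of what the source reports. "The series", "measured", "known", "first", "only" and "open" are said of these compounds alone.

In a functional assay on KM12 cells (Homo sapiens) for inhibition, read by sulforhodamine B assay, with a stated time of 96 h (a higher number here means a weaker inhibitor of growth, a lower number a stronger inhibitor of growth), compound 2 (`CC[C@H](Nc1nc(NCc2ccccn2)c2ncn(C(C)C)c2n1)C(C)O`) gives 23000 nM and compound 1 (`CCC(O)[C@@H](CC)Nc1nc(NCc2ccccn2)c2ncn(C(C)C)c2n1`) gives 45000 nM, so the two stand within the scatter of each other. Compound 3 (`CC[C@H](Nc1nc(NCc2ccccn2)c2ncn(C(C)C)c2n1)C(C)(C)O`) has methyl in place of hydrogen on a saturated chain carbon bound to an oxygen (methyl in place of hydrogen on a saturated chain carbon bound to an oxygen on a saturated carbon and two saturated chain carbons). Within the data shown here, the only measured step bearing on this change is a 2.0-fold lower number from compound 1 to compound 2 (0.29 log units; within the scatter), which alters the same chain and shows nothing beyond the scatter. The expected change is therefore small, a step of a 1.1-fold higher number from compound 2 to compound 3 (0.05 log units; within the scatter) with no firm direction. For compound 3 the estimate is 26000 nM (expected range 11000 nM to 60000 nM).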

Compound 3, concentration for 50% growth inhibition: 38000 nM
Beside the measured number, compound 3's estimate is 1.5-fold (0.16 log units) below it; low and high end bracket the measured number.
By their numbers in this assay, from the lowest: compounds 2, 3 and 1 (each within the scatter of the next).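

In this assay, going from 1-hydroxyethyl to 1-hydroxy-1-methylethyl gives a 1.7-fold higher number from compound 2 to compound 3 (0.22 log units; within the scatter), so methyl in place of hydrogen on this carbon shows no change beyond the scatter. The 1-(1-hydroxy-1-methylethyl)propyl chain, set against 1-ethyl-2-hydroxybutyl, gives a 1.2-fold lower number from compound 1 to compound 3 (0.07 log units; within the scatter), which leaves all three chains within the scatter of one another. Nothing available explains these values. The compounds shown leave open whether an amine or a carboxylic acid in place of the hydroxyl, or a longer chain on this carbon, would give a step beyond the scatter.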